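This account rests on a few compounds, and the source may have more. Where it says the series, first, only, none or still open, it means among the compounds named here.

Measured compounds:
compound 1 `O=C1/C(=C/c2ccccc2F)CN(C(=S)SCc2cn(Cc3ccccc3Cl)nn2)C/C1=C\c1ccccc1F` — in a functional assay on DU-145 cells (Homo sapiens) for cytotoxicity, read by MTT assay, with a stated time of 24 h (on this read-out higher numbers stand for weaker inhibition and lower numbers for stronger inhibition), compound 1 gives 46300 nM
compound 2 `O=C1/C(=C/c2ccccc2F)CN(C(=S)SCc2cn(Cc3ccc(F)cc3)nn2)C/C1=C\c1ccccc1F` — compound 2 gives 35700 nM
compound 3 `O=C1/C(=C/c2ccccc2F)CN(Cc2cn(Cc3ccccc3Cl)nn2)C/C1=C\c1ccccc1F` — compound 3 gives 7500 nM

Compounds 1 and 2 share one core; compound 3 carries a different core, and the difference between the two cores is not broken down here. Compound 3 stands lowest of the three numbers, with the gaps to compound 2 and to compound 1 both beyond the scatter.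

Going by the values given here, the only single-point change measured so far is 4-fluorophenyl in place of 2-chlorophenyl on a saturated chain carbon bound to an aromatic nitrogen, which gave a 1.3-fold lower number from compound 1 to compound 2 (0.11 log units; within the scatter). Compound 4 `O=C1/C(=C/c2ccccc2F)CN(Cc2cn(Cc3ccc(F)cc3)nn2)C/C1=C\c1ccccc1F` has not been measured. It differs from compound 3 by 4-fluorophenyl in place of 2-chlorophenyl on a saturated chain carbon bound to an aromatic nitrogen, the same change at the same place as between compound 1 and compound 2.

For compound 4 a step of a 1.3-fold lower number from compound 3 to compound 4 (0.10 log units; within the scatter) is expected, because the earlier instance of this change gave a 1.3-fold lower number from compound 1 to compound 2 (0.11 log units; within the scatter), a movement within the scatter. Compound 4 is therefore estimated at 6000 nM, with the range 2500 nM to 15000 nM; this rests on a single prior pair, and the core of compound 3 has not yet been probed with this change.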

Compound 4, half-maximal inhibitory concentration: 8700 nM
Estimate against measurement, compound 4: 1.5-fold (0.16 log units) below; low and high end bracket the measured number.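

In this assay, 4-fluorophenyl in place of 2-chlorophenyl on a saturated chain carbon bound to an aromatic nitrogen gives a 1.2-fold higher number from compound 3 to compound 4 (0.06 log units; within the scatter). Set beside the earlier instance, the change reads the same on both cores, with no difference that can be told from the scatter: the same change on two cores in this assay, a 1.3-fold lower number (0.11 log units; within the scatter) from compound 1 to compound 2 and a 1.2-fold higher number (0.06 log units; within the scatter) from compound 3 to compound 4, 1.5-fold (0.18 log units) apart, within the scatter of two such steps This shows only that the swap leaves the number unmoved on both cores; the opposite directions of the two steps cannot be read as an effect of the core, and a change this small does not test whether a step of real size would carry from one core to the other.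

The compounds shown leave open whether anything at this place moves the number beyond the scatter, as only the 2-chlorobenzyl and 4-fluorobenzyl groups appear there. A benzyl group carrying an amine or a carboxylic acid, or a longer chain in place of the benzyl carbon, would be a sharper test of transfer between the two cores.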